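Amide aryl variation on the flavonol series

This account rests on a few compounds, and the source may have more. Where it says the series, first, only, none or still open, it means among the compounds named here.

Three amides sharing one core have been measured in a functional assay on HCC1937 cells (Homo sapiens) for antiproliferative activity, read by CCK-8 assay, with a stated time of 72 h; on this read-out higher numbers stand for weaker inhibition and lower numbers for stronger inhibition. Compound 1 `COc1ccc(C(=O)Nc2cccc(-c3oc4cc(-c5ccc(F)cc5)ccc4c(=O)c3O)c2)cc1` gives 5490 nM. Compound 2 `COc1ccccc1C(=O)Nc1cccc(-c2oc3cc(-c4ccc(F)cc4)ccc3c(=O)c2O)c1` gives 9050 nM, and compound 3 `O=C(Nc1cccc(-c2oc3cc(-c4ccc(F)cc4)ccc3c(=O)c2O)c1)c1ccc(Br)cc1` gives 8630 nM. Compound 2 is not separated beyond the scatter from either neighbour: the step of a 1.6-fold higher number from compound 1 to compound 2 (0.22 log units; within the scatter) and the step of a 1.0-fold lower number from compound 2 to compound 3 (0.02 log units; within the scatter) both fall inside it, as does a 1.6-fold higher number from compound 1 to compound 3 (0.20 log units; within the scatter). So far the aryl on the carbonyl carbon has not moved this read-out in a way the assay can resolve.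

The next compound, compound 4 `COc1cc(OC)cc(C(=O)Nc2cccc(-c3oc4cc(-c5ccc(F)cc5)ccc4c(=O)c3O)c2)c1`, differs from compound 2 at that same carbonyl carbon: 3,5-dimethoxyphenyl in place of 2-methoxyphenyl on a carbonyl carbon. The relevant precedents are the two steps at this position, a 1.6-fold higher number from compound 1 to compound 2 (0.22 log units; within the scatter) and a 1.0-fold lower number from compound 2 to compound 3 (0.02 log units; within the scatter), each within the scatter, so no step beyond the scatter is expected in this assay for the change from compound 2 to compound 4, in either direction. The estimate for compound 4 in this assay is therefore 7500 nM, with a range from 3000 nM to 18000 nM. This estimate corresponds to an expected step of a 1.2-fold lower number from compound 2 to compound 4 (0.08 log units; within the scatter), which is within the scatter.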

Compound 4, half-maximal inhibitory concentration: 6250 nM
Beside the measured number, compound 4's estimate is 1.2-fold (0.08 log units) above it; low and high end bracket the measured number.
By their numbers in this assay, from the lowest: compounds 1, 4, 3 and 2 (each within the scatter of the next).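

Working notes, amide aryl position. In this assay, going by these compounds alone, the 3,5-dimethoxyphenyl on the carbonyl carbon is the first aryl here with two methoxy groups, and it stays inside the scatter of all three earlier amides: the steps read a 1.4-fold lower number from compound 2 to compound 4 (0.16 log units; within the scatter) and a 1.4-fold lower number from compound 3 to compound 4 (0.14 log units; within the scatter) and a 1.1-fold higher number from compound 1 to compound 4 (0.06 log units; within the scatter) with none resolved by the assay. The flat picture from the monosubstituted aryls therefore also holds for this larger aryl, which brings 10 heavy atoms and 2 hydrogen-bond acceptors where the 2-methoxyphenyl has 8 and 1, so neither count separates compound 4 from compound 2 on this read-out. No measurement at hand speaks to what lies behind this flat response.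

Still open, as far as these compounds go, is whether any replacement at this carbonyl carbon gives a step beyond the scatter, for instance an aryl carrying an amine or a carboxylic acid, or a longer alkyl chain in place of the aryl. Also open, from the compounds shown here alone, is whether the flat response here holds when the shared core is changed elsewhere, since all four compounds carry that core unchanged.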